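The source may report more compounds than this note shows. Statements on the series, on what has been measured and on what is new or still open speak of the compounds shown alone.

Measured compounds:
compound 1, `Cc1ccc(S/C(=C/c2ccc(N(C)C)cc2)C(=O)c2ccc(Cl)cc2)cc1`, > 100000 nM
compound 2, `COc1ccc(/C=C(/Sc2ccc(C)cc2)C(=O)c2ccc(Cl)cc2)cc1O`, 1000 nM
compound 3, `Cc1ccc(S/C(=C/c2ccc[nH]2)C(=O)c2ccc(Cl)cc2)cc1`, 10000 nM

In a functional assay on DU-145 cells (Homo sapiens) for inhibition, read by trypan blue exclusion, with a stated time of 96 h (on this read-out higher numbers stand for weaker inhibition of growth and lower numbers for stronger inhibition of growth), compound 1 gives only a limit, > 100000 nM, a boundary of the assay rather than a number (the limit of > 100000 nM in this assay, at which 1 of the 3 values shown sits). Compound 2 gives 1000 nM and compound 3 gives 10000 nM. Compound 1 thus stands at the weak end of what is shown: the step of an at least 100-fold lower number from compound 1 to compound 2 (2.00 log units; beyond the scatter) and the step of an at least 10-fold lower number from compound 1 to compound 3 (1.00 log units; beyond the scatter) both move away from it, while a 10-fold higher number from compound 2 to compound 3 (1.00 log units; beyond the scatter) separates the two numbered compounds.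

Compound 4, `CN(C)c1ccc(/C=C(/SCc2ccc(Cl)cc2)C(=O)c2ccc(Cl)cc2)cc1`, is not yet measured. It differs from compound 1 at the sulfur: 4-chlorobenzyl in place of 4-methylphenyl on a sulfur. Within the data shown here, none of the measured steps touches this sulfur; each of them replaces the group on the double-bonded chain carbon, so no step in hand bears on the change from 4-methylphenyl to 4-chlorobenzyl. Among the measured compounds shown here, with compound 1 at a limit and no guiding step, the estimate can only start from that limit. Compound 4 is expected near 100000 nM, between 10000 nM and 1000000 nM. The step this estimate implies, a number no higher from compound 1 to compound 4 (the limit leaves the size open), is expected to be uncertain in both direction and size.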

Compound 4, concentration for 50% growth inhibition: > 100000 nM
Compound 4 was reported as a limit; the forecaster's own chance of this, stated with the estimate: 60%; the middle value lies on the limit itself.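

Compound 1 and compound 4 both sit at a limit of the assay rather than at a number, so the step between them cannot be read: the limit of > 100000 nM in this assay, at which 2 of the 4 values shown sit. The compounds shown leave open what 4-chlorobenzyl in place of 4-methylphenyl on a sulfur does to growth inhibition.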